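Replacing the dichloroacetyl amide in a weak anilide

The source may hold more compounds than are shown below. What is called first, only, known or untested is meant among the compounds shown, and "the series" means these compounds.

Compound 1 `Nc1ccc(-c2nc3ccccc3s2)cc1I`: < 1 nM
Compound 2 `O=C(Nc1ccc(-c2nc3ccccc3s2)cc1)C(Cl)Cl`: > 100 nM
Compound 3 `O=C(Nc1ccc(-c2nc3ccccc3s2)cc1)c1ccccc1`: > 1000 nM

All three results come from a functional assay on MCF7 cells (Homo sapiens) for antiproliferative activity (a higher number here means a weaker inhibitor, a lower number a stronger inhibitor), and none of them is a number. Compound 1 gives < 1 nM, which is a limit. As far as these compounds go, compound 2 gives > 100 nM, which is also a limit, so its exact standing is unknown. Compound 3 gives > 1000 nM, again a limit.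

Compound 4 `C/C(S)=N/c1ccc(-c2nc3ccccc3s2)cc1` starts from compound 2 and makes one structural change: a group of 4 heavy atoms (2 carbon, 1 nitrogen, 1 sulfur; no ring) in place of a group of 6 heavy atoms (2 carbon, 1 nitrogen, 1 oxygen, 2 chlorine; no ring), on an aromatic carbon. The ((dichloromethyl)carbonyl)amino group leaves, and the shared core stays as it is.

Among the measured compounds shown here, only one measured step comes close to this change, a step that the two limits leave unreadable from compound 2 to compound 3. It alters the group on the carbonyl carbon and has no readable size, so it offers no size to carry over. Any expectation in this assay is therefore loose. It leans on compound 2, whose > 100 nM is a limit. Compound 4 is expected to remain on the weak side, and the data do not firmly fix a direction. The expected change is a step that the limit leaves unreadable from compound 2 to compound 4, a small shift towards weaker inhibition with wide uncertainty. For compound 4 the estimated value is 300 nM, with an expected range from 20 nM to 5000 nM.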

Compound 4, half-maximal inhibitory concentration: > 100 nM
Compound 4: a limit, no number (the forecaster's own chance of this, stated with the estimate: 50%); the middle value lies beyond the limit too.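

Among the compounds shown here, compound 2 and compound 4 are both reported only as limits in this assay, so no step between them can be read. The compounds shown leave open how far each lies beyond its limit, and so whether replacing the ((dichloromethyl)carbonyl)amino group with the group in compound 4 strengthens or weakens inhibition.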